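Swapping chloro for methoxy on an antifungal-type triazole

A few compounds are considered here, and "the series" means these few. Any claim that something is new, unique, unknown or untested is made for them only; others in the source may bear on it.

Of the compounds shown here, two of a shared core have been tested in an ADME assay on HEp-2 cells (Homo sapiens) for cytotoxicity, read by MTT assay, with a stated time of 3 days; on this read-out lower numbers stand for higher toxicity in this test and higher numbers for lower toxicity in this test. Compound 1 `CC[C@@H](CCn1cncn1)c1ccc(OC)cc1` gives 146 ug/mL in this assay. Compound 2 `CCCC[C@@H](CCn1cncn1)c1ccc(Cl)cc1` gives 17 ug/mL in this assay, the lowest of the two numbers, and the gap to compound 1 lies beyond the usual scatter. Going by the values given here, the two differ in two places at once, so no single step between them can be read. Compound 3 `CCCC[C@@H](CCn1cncn1)c1ccc(OC)cc1` is not yet measured. It carries the change methoxy in place of chloro on an aromatic carbon relative to compound 2, and nothing else. Among the compounds with values here, with no measured step for this change, the expectation rests on compound 1, whose methoxy-bearing structure gives the higher number 146 ug/mL in this assay. Compound 3 is therefore expected to move upward, a step of a 2.4-fold higher number from compound 2 to compound 3 (0.37 log units; beyond the scatter) of moderate size. The estimate for compound 3 in this assay is 40 ug/mL, with a range from 15 ug/mL to 120 ug/mL.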

Compound 3, half-maximal cytotoxic concentration: 31.6 ug/mL
For compound 3 the middle estimate is 1.3-fold (0.10 log units) above the measured one, within the range that was stated.
By their numbers in this assay, from the lowest: compounds 2 and 3 (each within the scatter of the next); then compound 1.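

In this assay, methoxy in place of chloro on an aromatic carbon, para to a large group, gives a 1.9-fold higher number from compound 2 to compound 3 (0.27 log units; within the scatter), so this swap cannot be told apart from the ordinary spread of repeat measurements. The chain change gives a clearer result: with methoxy held fixed, ethyl in place of hydrogen on a saturated chain carbon, three bonds along the chain from an aromatic carbon, gives a 4.6-fold lower number from compound 1 to compound 3 (0.66 log units; beyond the scatter), which makes the chain, not the ring group, the change that can be read in this small set. No supporting measurement explains this chain step. Still open, on these data alone, is whether the chain step keeps its size with chloro on the ring. Also open, as far as these compounds go, is how an amine or a carboxylic acid at that aromatic carbon, or a longer chain, would read.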